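The source may report more compounds than this note shows. Statements on the series, on what has been measured and on what is new or still open speak of the compounds shown alone.

Compound 2 `Cc1ccc(-c2csc(=N)n2CC(=O)N2CCN(C)CC2)cc1` is the reference point of this account. In an assay on isolated protein for inhibition of leukotriene A-4 hydrolase (Homo sapiens) (a lower number here means a stronger inhibitor, a higher number a weaker inhibitor), compound 2 gives 369 nM, the lowest of the three numbers measured, though that position is not separable from its nearest neighbour: compound 3 `CN1CCN(C(=O)Cn2c(-c3ccccc3)csc2=N)CC1`, which carries a hydrogen in place of the methyl on an aromatic carbon, gives 629 nM, and the step of a 1.7-fold higher number from compound 2 to compound 3 (0.23 log units; within the scatter) does not count. The other neighbour is compound 1 `Cc1ccc(-c2csc(=N)n2CC(=O)N2CCN(c3ccccc3)CC2)cc1`, which gives 4290 nM in this assay; the step of a 12-fold lower number from compound 1 to compound 2 (1.07 log units; beyond the scatter) is the one clear effect in the set, and it arises at the amine nitrogen in the ring.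

Compound 4 `CC(=O)N1CCN(C(=O)Cn2c(-c3ccc(C)cc3)csc2=N)CC1` alters that same nitrogen: acetyl in place of methyl on an amine nitrogen in a ring. Among the measured compounds shown here, only the step from compound 1 to compound 2 bears on this change, and it shows that what sits on this ring nitrogen can move the number a long way. An acetyl is neither a methyl nor a phenyl, so the direction is uncertain, but some weakening is the more likely reading, and the expected step is a 2.7-fold higher number from compound 2 to compound 4 (0.43 log units; beyond the scatter). Compound 4 is therefore estimated at 1000 nM in this assay, within a range of 350 nM to 3000 nM.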

Compound 4, inhibition constant: 1640 nM
For compound 4 the middle estimate is 1.6-fold (0.21 log units) below the measured one; the range from low to high includes it.
By their numbers in this assay, from the lowest: compounds 2 and 3 (each within the scatter of the next); then compound 4; then compound 1.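

With acetyl on the amine nitrogen in the ring, the number lands at neither end of what this nitrogen has shown so far: there is a 4.4-fold higher number from compound 2 to compound 4 (0.65 log units; beyond the scatter), yet also a 2.6-fold lower number from compound 1 to compound 4 (0.42 log units; beyond the scatter). The earlier contrast of methyl and phenyl thus becomes a three-member order in this assay, running from methyl through acetyl to phenyl, with every gap in that order lying beyond the scatter and holding for these three compounds alone. Nothing at hand bears on what sets the acetyl in its place in that order.

The compounds shown leave open where a bare amine hydrogen, an ethyl or longer chain, or a sulfonyl group on this nitrogen would fall in that order. Among the compounds shown here, they also leave open whether the acetyl step would be of similar size with hydrogen in place of the methyl on the aromatic carbon, since compound 3 , the one compound with that hydrogen, carries methyl on the ring nitrogen.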